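Thiadiazole for methyltetrazole on the thioether sulfur

The source may hold more compounds than are shown below. What is called first, only, known or untested is meant among the compounds shown, and "the series" means these compounds.

Measured compounds:
- compound 1 `O=C(Nc1ccc(O)c(Sc2nncs2)c1)c1ccc([N+](=O)[O-])cc1`: "not active" (no number reported)
- compound 2 `Cn1nnnc1Sc1cc(NS(=O)(=O)c2ccc([N+](=O)[O-])cc2)ccc1O`: 11.5%
- compound 3 `Cc1nnc(Sc2cc(NC(=O)c3ccc([N+](=O)[O-])cc3)ccc2O)s1`: 12.4%

In an assay on isolated protein for inhibition of RAC-alpha serine/threonine-protein kinase (Homo sapiens), read by fluorescence, with a stated time of 30 min, tested at 10 uM (a lower number here means less inhibition, a higher number more inhibition at the concentration tested (going by the name of the read-out)), compound 1 gives "not active" (no number reported), a verdict reported as not active, with no number attached. In this assay compound 2 gives 11.5%, the lower of the two reported numbers, and compound 3 gives 12.4%; the two numbers lie within the usual scatter of each other, so they can only be called level. The two numbers are low at the concentration tested.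

Compound 4 `O=[N+]([O-])c1ccc(S(=O)(=O)Nc2ccc(O)c(Sc3nncs3)c2)cc1` is not yet measured. It differs from compound 2 in one place: 1,3,4-thiadiazol-2-yl in place of 1-methyl-1H-tetrazol-5-yl on a sulfur. Going by the values given here, no step between measured compounds isolates this change, so no measured size is available for it. Given that compound 2 and compound 3 sit at low, level values and compound 1 is reported as not active, the expected step of a number 1.5 percentage points lower from compound 2 to compound 4 (within the scatter) is none beyond the scatter. Compound 4 is therefore expected to give 10%, in the range 0% to 25%.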

Compound 4, a percentage reported as inhibition, at one concentration (the size of the read-out at that concentration, not a potency): 14.9%
Estimate against measurement, compound 4: 4.9 percentage points below, within the range that was stated.
By their numbers in this assay, from the lowest: compounds 2, 3 and 4 (each within the scatter of the next).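

In this assay, 1,3,4-thiadiazol-2-yl in place of 1-methyl-1H-tetrazol-5-yl on a sulfur gives a number 3.4 percentage points higher from compound 2 to compound 4 (within the scatter), so this exchange now has a measured size, and that size stays inside the scatter. The same 1,3,4-thiadiazol-2-yl now has a number on the sulfonyl-linked core, where compound 4 gives 14.9%, while compound 1, with the amide link, is reported as "not active" (no number reported), so no step can be read for that pair. The data shown offer no explanation for the result.

Still open, on these data alone, is whether any other group on this sulfur, such as a plain phenyl ring or a carboxylic acid on a short chain, would move the number beyond the scatter. Also open, as far as these compounds go, is what an amine in place of the nitro group would do on either link.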